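Adding an Isobutyl Branch to a Weakly Active Anilide

The source may hold more compounds than are shown below. What is called first, only, known or untested is meant among the compounds shown, and "the series" means these compounds.

Of the compounds shown here, three have been measured in a functional assay, read by spectrophotometry, with a stated time of 20 min; a higher number here means a weaker inhibitor, a lower number a stronger inhibitor. Compound 1 `CC(=O)c1ccc(NC(=O)C(CC(C)C)N(C(=O)c2ccccc2)S(=O)(=O)c2ccc(C)cc2)cc1` gives 11000000 nM in this assay. Compound 2 `CC(=O)c1ccc(NC(=O)C(CC(C)C)N(C(=O)c2ccccc2)S(=O)(=O)c2ccc([N+](=O)[O-])cc2)cc1` gives 8400000 nM. Compound 3 `CC(=O)c1ccc(NC(=O)CN(C(=O)c2ccccc2)S(=O)(=O)c2ccccc2)cc1` gives 32000000 nM, the highest number of the three; compound 1 sits nearest to it and compound 2 furthest, both gaps lying beyond the scatter. Among the compounds with values here, the only single-point step among the measured compounds is a 1.3-fold lower number from compound 1 to compound 2 (0.12 log units; within the scatter), so exchanging the group on that aromatic carbon hardly moves the number.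

Compound 4 `CC(=O)c1ccc(NC(=O)C(CC(C)C)N(C(=O)c2ccccc2)S(=O)(=O)c2ccccc2)cc1` differs from compound 3 by isobutyl in place of hydrogen on a saturated chain carbon bound to an amide-type nitrogen and a carbonyl carbon. Within the data shown here, no measured pair isolates this change on its own. The nearest guide is compound 1, which carries the same isobutyl together with a methyl on an aromatic carbon, and its value is lower than that of compound 3 by more than the scatter, while compound 2, carrying a nitro in place of that methyl, shows much the same number as compound 1. On that basis the step of a 2.9-fold lower number from compound 3 to compound 4 (0.46 log units; beyond the scatter) is expected, a lowering of the number in this assay. Compound 4 is therefore estimated at 11000000 nM in this assay, with a range from 5000000 nM to 25000000 nM.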

Compound 4, half-maximal inhibitory concentration: 3200000 nM
For compound 4 the middle estimate is 3.4-fold (0.54 log units) above the measured one; measured number outside the range, below it.
By their numbers in this assay, from the lowest: compound 4; then compounds 2 and 1 (each within the scatter of the next); then compound 3.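

In this assay, isobutyl in place of hydrogen on a saturated chain carbon bound to an amide-type nitrogen and a carbonyl carbon now has a direct measurement free of any second change: a 10-fold lower number from compound 3 to compound 4 (1.00 log units; beyond the scatter). The aromatic carbon also proves more sensitive than the earlier pair suggested, since compound 1 and compound 2 lie within the scatter of each other, yet with the isobutyl kept, hydrogen in place of methyl gives a 3.4-fold lower number from compound 1 to compound 4 (0.54 log units; beyond the scatter) and hydrogen in place of nitro gives a 2.6-fold lower number from compound 2 to compound 4 (0.42 log units; beyond the scatter). Nothing available explains either shift.

The compounds shown do not tell whether a smaller methyl or a longer chain such as n-hexyl at the saturated chain carbon would move the number further, or whether the preference for hydrogen on the aromatic carbon would hold without the isobutyl, as no methyl or nitro compound lacks that group. Nor do they show how an amine or a fluorine on that aromatic carbon would compare with hydrogen.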